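Changing the Amine End: From a Ring to an Open Chain

The compounds below may be only part of what the source reports. "The series", "measured", "known", "first", "only" and "open" are said of these compounds alone.

The measured compounds and their results in an ADME assay on HEK-293T cells (Homo sapiens) for cytotoxicity, read by MTT assay, with a stated time of 48 h; a lower number here means that less compound is tolerated, a higher number that more compound is tolerated:
compound 1 `CC1(C)[C@H]2CC[C@]1(C)[C@H](OC(=O)CCCCN1CCCCC1)C2` gives 101000 nM
compound 2 `CC1CCN(CC(=O)O[C@@H]2C[C@@H]3CC[C@@]2(C)C3(C)C)CC1` gives 71600 nM
compound 3 `CN1CCN(CCCC(=O)O[C@@H]2C[C@@H]3CC[C@@]2(C)C3(C)C)CC1` gives 99200 nM

All three share the same core, joined through an ester to a chain that ends in a basic amine; they differ only in the shape of that amine end and the length of the chain. Their three values lie within the usual scatter of one another, so compound 2 cannot be set apart from compound 1 or compound 3 on these numbers. Within the data shown here, the only measured step between compounds that differ in one place, a 1.0-fold lower number from compound 1 to compound 3 (0.01 log units; within the scatter), also swapped one amine end for another and stayed within the scatter.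

Compound 4 `CCN(CC)CCC(=O)O[C@@H]1C[C@@H]2CC[C@@]1(C)C2(C)C` has not yet been measured. Its change from compound 2 is (diethylamino)methyl in place of 4-methylpiperidin-1-yl on a saturated chain carbon bound to a carbonyl carbon. This again touches only the amine end, and the step from compound 1 to compound 3 shows such a swap leaving the number essentially unchanged. The expectation is therefore a step of a 1.1-fold higher number from compound 2 to compound 4 (0.05 log units; within the scatter), within the scatter, in no clear direction. Compound 4 is estimated at 80000 nM in this assay, with a range from 40000 nM to 160000 nM.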

Compound 4, half-maximal cytotoxic concentration: 327000 nM
For compound 4 the middle estimate is 4.1-fold (0.61 log units) below the measured one; measured number above the stated range.
By their numbers in this assay, from the lowest: compounds 2, 3 and 1 (each within the scatter of the next); then compound 4.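

In this assay, among these compounds, swapping the amine end on a saturated chain carbon bound to a carbonyl carbon can matter: replacing the 4-methylpiperidin-1-yl ring with open-chain (diethylamino)methyl gives a 4.6-fold higher number from compound 2 to compound 4 (0.66 log units; beyond the scatter) and is the first step here to pass beyond the scatter. The earlier swap of one ring amine for another, a 1.0-fold lower number from compound 1 to compound 3 (0.01 log units; within the scatter) at a different place on the chain, gave no hint of this, so an amine swap does not always leave the number unchanged.

With only one open-chain amine among these compounds, a single step cannot show whether opening the ring matters or whether the particular groups do. A dimethylamino end or a morpholine ring at the same place would help separate these readings, and nothing available here explains the rise.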